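Removing a trifluoromethyl group from a triazole-linked phenyl ring

The source may report more compounds than this note shows. Statements on the series, on what has been measured and on what is new or still open speak of the compounds shown alone.

Compounds measured so far:
compound 1, `Cc1ccc(S(=O)(=O)Oc2ccc3c(c2C)[C@H](Cn2cc(-c4ccccc4)nn2)[C@@]24CC(=O)[C@@](C)(CC[C@@H]32)C4)cc1`, > 20000 nM
compound 2, `C=C1C[C@]23C[C@@]1(O)CC[C@H]2c1ccc(O)c(C)c1[C@@H]3Cn1cc(-c2ccc(C(F)(F)F)cc2)nn1`, 8950 nM

Of the compounds shown here, two have been tested in a functional assay on HL-60 cells (Homo sapiens) for cytotoxicity, read by MTT assay, with a stated time of 4 days; a lower number here means a stronger inhibitor, a higher number a weaker inhibitor. For compound 1 `Cc1ccc(S(=O)(=O)Oc2ccc3c(c2C)[C@H](Cn2cc(-c4ccccc4)nn2)[C@@]24CC(=O)[C@@](C)(CC[C@@H]32)C4)cc1` the result is only a limit of the assay, > 20000 nM, and not a number. Among the measured compounds shown here, compound 2 `C=C1C[C@]23C[C@@]1(O)CC[C@H]2c1ccc(O)c(C)c1[C@@H]3Cn1cc(-c2ccc(C(F)(F)F)cc2)nn1` is therefore the only compound with a numerical value, giving 8950 nM in this assay . For the measured compounds named here, no step between two measured compounds that differ in a single place is available, so there is no measured step on which to lean.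

Compound 3 `C=C1C[C@]23C[C@@]1(O)CC[C@H]2c1ccc(O)c(C)c1[C@@H]3Cn1cc(-c2ccccc2)nn1` differs from compound 2 in one place: hydrogen in place of trifluoromethyl on an aromatic carbon, para to a large group. Going by the values given here, with no comparable step among the measured compounds, the direction of this change cannot be read from the data. The expectation is a modest loss, which may stay within the scatter, with the step from compound 2 to compound 3 estimated as a 1.7-fold higher number from compound 2 to compound 3 (0.22 log units; within the scatter). Compound 3 is thus expected to give about 15000 nM in this assay , with a range from 5000 nM to 40000 nM.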

Compound 3, half-maximal inhibitory concentration: > 20000 nM
Compound 3: a limit, no number (the forecaster's own chance of this, stated with the estimate: 35%); middle value at least 1.3-fold (0.12 log units) from the limit.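

Among the compounds shown here, replacing trifluoromethyl with hydrogen on the aromatic carbon, para to a large group, gives the first measured step in this assay: an at least 2.2-fold higher number from compound 2 to compound 3 (0.34 log units; beyond the scatter). For the compounds shown here, compound 3 gives > 20000 nM, which is a limit of the assay and not a number, so the trifluoromethyl group is the one difference between the compound with a numerical value and this compound without one. The step is only a lower bound, and its full size cannot be read because the measurement stops at a limit: the limit of > 20000 nM in this assay, at which 2 of the 3 values shown sit.

As far as these compounds go, whether an amine, a carboxylic acid or a methoxy group at this same position would give a lower or a higher number than trifluoromethyl remains open, so this single pair does not show whether trifluoromethyl is a particularly good group here or simply better than hydrogen. From the compounds shown here alone, compound 1 differs from compound 2 and compound 3 in more than one place, so it adds nothing on this change, and the effect of the same swap on a different core also remains unknown.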